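A thiazole replaces the furan on the ring nitrogen

A few compounds are considered here, and "the series" means these few. Any claim that something is new, unique, unknown or untested is made for them only; others in the source may bear on it.

Compound 1 `O=C(NCc1ccc(Cl)cc1Cl)[C@@H]1CCC(=O)N1c1ccsc1`: 256 nM
Compound 2 `O=C(NCc1ccc(Cl)cc1Cl)[C@@H]1CCC(=O)N1c1ccoc1`: 86 nM

Both compounds were tested in an assay on HEK293 cells for displacement of a labelled ligand from P2X purinoceptor 7 (Homo sapiens), read by scintillation counting, with a stated time of 1 h; a higher number here means a weaker inhibitor, a lower number a stronger inhibitor. Compound 2 holds the lowest of the two numbers; its nearest neighbour is compound 1, and the step of a 3.0-fold lower number from compound 1 to compound 2 (0.47 log units; beyond the scatter) is modest but beyond the scatter. Compound 3 `O=C(NCc1ccc(Cl)cc1Cl)[C@@H]1CCC(=O)N1c1nccs1` is not yet measured. It differs from compound 2 in one place: 1,3-thiazol-2-yl in place of furan-3-yl on an amide-type nitrogen in a ring. Among the measured compounds shown here, no measured step covers this exact exchange. For the measured compounds named here, the only step that bears on it, a 3.0-fold lower number from compound 1 to compound 2 (0.47 log units; beyond the scatter), shows that swapping one five-membered aromatic ring for another on this nitrogen moved the number modestly, with the ring containing sulfur giving the higher number. The entering group again contains sulfur but also a nitrogen, so the direction is uncertain, and a modest shift either way would not be surprising. Compound 3 is expected to give 150 nM, within a range of 50 nM to 500 nM. The expected step is a 1.7-fold higher number from compound 2 to compound 3 (0.24 log units; within the scatter), which is an estimate rather than a measurement.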

Compound 3, inhibition constant: 489 nM
The estimate for compound 3 lay 3.3-fold (0.51 log units) below the measured number; the range from low to high includes it.
By their numbers in this assay, from the lowest: compound 2; then compounds 1 and 3 (each within the scatter of the next).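

Among the compounds shown here, on an amide-type nitrogen in a ring, the 1,3-thiazol-2-yl group gives a 5.7-fold higher number from compound 2 to compound 3 (0.75 log units; beyond the scatter), a step beyond the scatter and larger than the one first seen for this position, which makes furan-3-yl the only group of the three with a number clearly apart from the others in this assay. Compound 3 shows a 1.9-fold higher number from compound 1 to compound 3 (0.28 log units; within the scatter), so the two sulfur-containing rings cannot be told apart here, even though the 1,3-thiazol-2-yl group carries a ring nitrogen and the thiophen-3-yl group does not. Nothing at hand explains why the furan-3-yl compound stands apart from the two sulfur-containing rings.

The three compounds leave open whether the gap follows the ring's hetero atoms or the point at which the ring is attached, since compound 2 and compound 3 differ in both; a furan-2-yl, a 1,3-oxazol-2-yl or a plain phenyl ring on the same nitrogen would help separate them. From the compounds shown here alone, whether the same order holds when the shared 2,4-dichlorobenzyl amide is replaced, for example by an unsubstituted benzyl amide, also remains open.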